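Swapping a Bromophenyl for a Pyrimidinyl Group

The source may hold more compounds than are shown below. What is called first, only, known or untested is meant among the compounds shown, and "the series" means these compounds.

Compound 1 `Cc1c(C2CC2)nc2ccc(-n3ccc(OCc4ccc(Br)cc4)cc3=O)cn12` in an assay on CHO cells for displacement of a labelled ligand from melanin-concentrating hormone receptor 1 (Rattus norvegicus), read by scintillation counting, with a stated time of 1 h (on this read-out lower numbers stand for stronger inhibition and higher numbers for weaker inhibition), gives 9.3 nM.
Compound 2 `COCc1nc2ccc(-n3ccc(OCc4ccc(F)cc4)cc3=O)cn2c1C` in this assay returns only a limit, > 1000 nM.

Among the compounds with values here, compound 1 therefore carries the only numerical result here; compound 2 sits at the limit described by the limit of > 1000 nM in this assay, at which 1 of the 2 values shown sits, and since the two compounds differ in more than one place, no single step between them can be read. Compound 3 `Cc1c(C2CC2)nc2ccc(-n3ccc(OCc4cncnc4)cc3=O)cn12` has not yet been measured. It departs from compound 1 by pyrimidin-5-yl in place of 4-bromophenyl on a saturated chain carbon bound to an oxygen on an aromatic ring. Without a measured step of this kind to lean on, the expectation rests on compound 1 alone, and the replacement is expected to cost binding in this assay by more than the usual scatter, so that the step from compound 1 to compound 3 is estimated at a 16-fold higher number from compound 1 to compound 3 (1.21 log units; beyond the scatter). Compound 3 is accordingly expected to give about 150 nM, within a range of 30 nM to 1000 nM.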

Compound 3, half-maximal inhibitory concentration: > 1000 nM
Compound 3: only a limit was reported (the forecaster's own chance of this, stated with the estimate: 25%); at least 6.6-fold (0.82 log units) between middle value and limit.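

Within the data shown here, the swap of 4-bromophenyl for pyrimidin-5-yl on a saturated chain carbon bound to an oxygen on an aromatic ring is the only single change that can be read here, and in this assay it amounts to an at least 100-fold higher number from compound 1 to compound 3 (2.03 log units; beyond the scatter). In this assay compound 3 gives > 1000 nM, which is a limit and not a number. Compound 2 differs from compound 1 and compound 3 in more than one place and no step to it can be read, yet compound 3 now stands with it at the same limit: the limit of > 1000 nM in this assay, at which 2 of the 3 values shown sit.

The step changes the ring and removes the bromine in one move, so the compounds shown leave open which of the two accounts for it. A plain phenyl or a pyridinyl group in the same place would separate them.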